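The compounds below may be only part of what the source reports. "The series", "measured", "known", "first", "only" and "open" are said of these compounds alone.

Measured compounds:
compound 1 `N[C@H]1CC[C@H](Nc2c(C(=O)NCc3ccco3)nc(Br)c3cccnc23)CC1` — "not determined" (no result reported)
compound 2 `NCCCNc1c(C(=O)NCc2ccc(F)cc2)nc(Br)c2cccnc12` — 6000 nM
compound 3 `C[C@H](CO)Nc1nc(C(=O)NCc2ccc(F)cc2)c(O)c2ncccc12` — "not determined" (no result reported)

The three compounds share a core, and only compound 2 carries a number: in a functional assay on MCF7 cells (Homo sapiens) for cytotoxicity, read by MTT assay, with a stated time of 72 h (on this read-out higher numbers stand for weaker inhibition and lower numbers for stronger inhibition), compound 2 gives 6000 nM. For compound 1 the outcome in this assay is recorded as "not determined" (no result reported), and for compound 3 likewise as "not determined" (no result reported), so compound 1 stands without any number of its own and without a neighbour measured one change away.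

The new compound is compound 4 `N[C@H]1CC[C@H](Nc2c(C(=O)NCc3cccs3)nc(Br)c3cccnc23)CC1`. Against compound 1 the difference is thiophen-2-yl in place of furan-2-yl on a saturated chain carbon bound to an amide-type nitrogen. Going by the values given here, no measured pair shows what this exchange does, and compound 2, the only numbered compound, differs from both in more than one place. The group that leaves and the group that enters match in ring size, in hetero atom count and in donor and acceptor count. The step from compound 1 to compound 4 in this assay is expected to be none beyond the usual scatter, in either direction.

Resting on compound 2 at 6000 nM as the only anchor, compound 4 is estimated at 4000 nM in this assay, with a range from 800 nM to 20000 nM.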

Compound 4, half-maximal inhibitory concentration: 7300 nM
Compound 4: the middle estimate sits 1.8-fold (0.26 log units) below what was measured; measured number inside the range.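

In this assay, going by these compounds alone, compound 1 is recorded as "not determined" (no result reported), and no step from it to compound 4 can be read. The compounds shown leave open what the exchange of furan-2-yl for thiophen-2-yl does in this assay. No available evidence bears on the result.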